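This account rests on a few compounds, and the source may have more. Where it says the series, first, only, none or still open, it means among the compounds named here.

In a functional assay on SW480 cells (Homo sapiens) for antiproliferative activity, read by MTT assay, with a stated time of 48 h (on this read-out lower numbers stand for stronger inhibition and higher numbers for weaker inhibition), the measured compounds give these values:
Compound 1 `CC(CCO)n1cnc2c(Cl)nc(F)nc21` gives 16800 nM
Compound 2 `CCCC(CCO)n1cnc2c(Cl)nc(F)nc21` gives 17200 nM
Compound 3 `CCCCCC(CCO)n1cnc2c(Cl)nc(F)nc21` gives 7440 nM

Compound 3 has the lowest number of the three, beyond the scatter from both others. Compound 4 `OCCCn1cnc2c(Cl)nc(F)nc21` differs from it by hydrogen in place of pentyl on a saturated chain carbon bound to an aromatic nitrogen and a saturated chain carbon and so carries hydrogen in place of pentyl on a saturated chain carbon bound to an aromatic nitrogen and a saturated chain carbon. Within the data shown here, no measured compound has hydrogen there. The closest evidence is a 2.3-fold lower number from compound 2 to compound 3 (0.36 log units; beyond the scatter) and a 2.3-fold lower number from compound 1 to compound 3 (0.35 log units; beyond the scatter) as modest steps, whereas a 1.0-fold higher number from compound 1 to compound 2 (0.01 log units; within the scatter) stays within the scatter. A modest rise is therefore expected, estimated as a 2.7-fold higher number from compound 3 to compound 4 (0.43 log units; beyond the scatter) in this assay overall. Compound 4 is estimated at 20000 nM with an expected range from 10000 nM to 40000 nM in this read-out.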

Compound 4, half-maximal inhibitory concentration: 29700 nM
Compound 4: the middle estimate sits 1.5-fold (0.17 log units) below what was measured; the measured number falls inside the stated range.
By their numbers in this assay, from the lowest: compound 3; then compounds 1, 2 and 4 (each within the scatter of the next).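

In this assay, among these compounds, hydrogen in place of pentyl on this carbon gives a modest rise (a 4.0-fold higher number from compound 3 to compound 4 (0.60 log units; beyond the scatter)), the largest step so far. Hydrogen in place of propyl (a 1.7-fold higher number from compound 2 to compound 4 (0.24 log units; within the scatter)) or of methyl (a 1.8-fold higher number from compound 1 to compound 4 (0.25 log units; within the scatter)) stays within the scatter, so among these compounds only pentyl sets its compound apart from the unsubstituted chain. No evidence is available that explains this difference.

On these data alone, whether a longer chain such as octyl would lower the number further remains open. So does the effect of a phenyl ring or an amine at this carbon.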